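From 2-Methoxyethyl to 3-Methoxypropyl on the Amine

The source may hold more compounds than are shown below. What is called first, only, known or untested is meant among the compounds shown, and "the series" means these compounds.

Measured in a toxicity assay on EA.hy 926 cells (Homo sapiens) for cytotoxicity, read by MTT assay, with a stated time of 48 h; a lower number here means a stronger inhibitor, a higher number a weaker inhibitor:

Compound 1 `COCCCN1C(/C=C/c2ccc(O)cc2)=CC(=O)CC1c1ccc(O)cc1`: a limit, > 100000 nM
Compound 2 `COc1cc(/C=C/C(=O)/C=C(/C=C/c2ccc(O)c(OC)c2)NCCCO)ccc1O`: a limit, > 100000 nM
Compound 3 `COCCNC(=C\C(=O)/C=C/c1ccc(O)cc1)/C=C/c1ccc(O)cc1`: 45100 nM

Compound 3 is the only one of the three that gives an actual number in this assay; the other two sit at the limit of > 100000 nM in this assay, at which 2 of the 3 values shown sit, so nothing can be said about how they order against compound 3 or each other. Compound 4 `COCCCNC(=C\C(=O)/C=C/c1ccc(O)cc1)/C=C/c1ccc(O)cc1` is the untested partner of compound 3. The change is small: methoxymethyl in place of methoxy on a saturated chain carbon, two bonds along the chain from an amine nitrogen. Among the compounds with values here, no pair of tested compounds shows what this change does, so the expectation rests on the size of the change alone: a step in this assay of about no size beyond the scatter, in either direction. Compound 4 is therefore expected to give 50000 nM, with a range from 20000 nM to 120000 nM. That expected step is a 1.1-fold higher number from compound 3 to compound 4 (0.04 log units; within the scatter).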

Compound 4, half-maximal inhibitory concentration: 81900 nM
Beside the measured number, compound 4's estimate is 1.6-fold (0.21 log units) below it; the measured number falls inside the stated range.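

In this assay, going from 2-methoxyethyl to 3-methoxypropyl on the amine comes with a 1.8-fold higher number from compound 3 to compound 4 (0.26 log units; within the scatter). Within the data shown here, this is the first pair here in which this single change can be read, and the two compounds cannot be told apart, so the longer chain keeps a measurable number at this position. Compounds 1 and 2 differ in more than one place and give no number to compare: the limit of > 100000 nM in this assay, at which 2 of the 4 values shown sit.

Still open, on these data alone, is whether a longer chain, such as 4-methoxybutyl, or a carboxylic acid at the chain end would separate clearly from compound 3. Also open, as far as these compounds go, is whether this change would behave the same way on a different core.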